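This account rests on a few compounds, and the source may have more. Where it says the series, first, only, none or still open, it means among the compounds named here.

Series notes. Compound 1 `CC1=C(C(=O)Nc2ccc([N+](=O)[O-])cc2)C(c2cccc([N+](=O)[O-])c2)N=C(SCc2ccccc2Cl)N1` and compound 2 `CC1=C(C(=O)Nc2ccc([N+](=O)[O-])cc2)C(c2cccc([N+](=O)[O-])c2)N=C(SCc2ccc(Cl)cc2)N1` share one core and differ only in the chlorobenzyl group bound through sulfur. In a functional assay on the whole organism (artery, strain albino) with Rattus norvegicus as the target, with a stated time of 15 min, at a dose of 10 mg/kg by the oral route (a lower number here means less inhibition, a higher number more inhibition at the dose given (going by the name of the read-out)), compound 1 gives 2.1%, and compound 2 gives 2.1%. The step of no change at the digits printed from compound 1 to compound 2 (within the scatter) leaves the read-out where it was, and compound 2 is level with compound 1 at the digits shown, with no order between them.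

Compound 3 `CC1=C(C(=O)Nc2ccc([N+](=O)[O-])cc2)C(c2cccc([N+](=O)[O-])c2)N=C(SCc2ccc(F)cc2)N1` keeps the core of compound 2 and changes the halogen on the benzyl group: fluoro in place of chloro on an aromatic carbon, or, taken one bond further out, 4-chlorobenzyl to 4-fluorobenzyl. Within the data shown here, the only measured step that bears on this part of the structure is no change at the digits printed from compound 1 to compound 2 (within the scatter), which moved the chlorine on the same ring without any shift beyond the scatter. Among the measured compounds shown here, no measured step exchanges one halogen for another, so the expectation rests on that single step alone. The expected step of a number 0.1 percentage points lower from compound 2 to compound 3 (within the scatter) is therefore none beyond the scatter, in either direction. Compound 3 is estimated at 2% in this assay, with a range from 0% to 12%.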

Compound 3, a percentage reported as inhibition, in the whole organism at one dose (the size of the read-out at that dose, not a potency): 2.6%
Compound 3: middle estimate off by 0.6 percentage points, on the low side; low and high end bracket the measured number.
By their numbers in this assay, from the lowest: compounds 1, 2 and 3 (each within the scatter of the next).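

In this assay, among these compounds, fluoro in place of chloro on an aromatic carbon, para to a large group, gives a number 0.5 percentage points higher from compound 2 to compound 3 (within the scatter) and so adds the first exchange of one halogen for another to the series, and at this position the two halogens cannot be told apart. The wider step a number 0.5 percentage points higher from compound 1 to compound 3 (within the scatter) replaces 2-chlorophenyl with 4-fluorophenyl and also stays within the scatter, so the halogen and its place on the ring have shown no measurable effect on this read-out across these three compounds. The data hold nothing that could explain this outcome.

The compounds shown leave open whether any group on this ring can move the read-out, since only chloro and fluoro appear there; a methoxy group, an amine or a carboxylic acid on the ring, or a longer chain between the sulfur and the ring, would test that. They also leave open what the nitro groups and the amide contribute, as all three compounds carry these parts unaltered.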